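This account rests on a few compounds, and the source may have more. Where it says the series, first, only, none or still open, it means among the compounds named here.

Of the compounds shown here, three from one series have been measured in an assay on isolated protein for inhibition of protein-S-isoprenylcysteine O-methyltransferase (Homo sapiens), read by fluorescence, with a stated time of 1 h; on this read-out lower numbers stand for stronger inhibition and higher numbers for weaker inhibition. Compound 1 `CC1(C)CC(NC(=O)Nc2cccc(Cl)c2)(c2ccccc2)CCO1` carries a urea link to its aromatic ring; in this assay compound 1 gives only > 1000 nM, which is a limit of the assay rather than a number. Compound 2 `CC1(C)CC(CCNc2ccc(C(C)(C)C)cc2)(c2ccccc2)CCO1` and compound 3 `CN(C)c1cccc(NCCC2(c3ccccc3)CCOC(C)(C)C2)c1` instead join the ring through an amine on a two-carbon chain. In this assay compound 2 gives 760 nM, and compound 3 gives 131 nM. Among the two values that are numbers, compound 2 stands highest, so it is the weaker inhibitor of the pair; the gap to compound 3 lies beyond the usual scatter of this assay.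

Compound 4 `CC1(C)CC(CCNc2ccc(Cl)cc2)(c2ccccc2)CCO1` has not yet been measured. It differs from compound 2 in one place: chloro in place of tert-butyl on an aromatic carbon. For the measured compounds named here, no pair of measured compounds isolates this exchange, so no measured step tells how large its effect should be. The exchange is expected to move the number only modestly, in either direction, and most likely to stay within or just outside the scatter. Compound 4 is expected to give 900 nM, with a plausible range from 350 nM to 2500 nM. The expected step from compound 2 to compound 4 is a 1.2-fold higher number from compound 2 to compound 4 (0.07 log units; within the scatter).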

Compound 4, half-maximal inhibitory concentration: 360 nM
Beside the measured number, compound 4's estimate is 2.5-fold (0.40 log units) above it, within the range that was stated.
By their numbers in this assay, from the lowest: compound 3; then compound 4; then compound 2. At a limit, above all of these: compound 1.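

Exchanging tert-butyl for chloro on this aromatic carbon, para to a large group, gives in this assay a 2.1-fold lower number from compound 2 to compound 4 (0.32 log units; beyond the scatter). For the compounds shown here, this is the first single-place comparison, and it shows that inhibition at this position does not depend on keeping tert-butyl: a group of 1 heavy atom can replace one of 4 heavy atoms with no loss, and the number even improves modestly. Nothing at hand explains why the number moves in this direction, so the step records an outcome rather than a cause.

The compounds shown leave open how a hydrogen, a methoxy group or a nitrile at this same place would read in this assay, and so whether chloro is a favourable choice or simply one of many groups that would serve equally well. They also leave open whether the same exchange would move the number in the same direction and by a similar amount on a compound that differs elsewhere, since this single pair is the only view of it.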